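Methylaminomethyl for Ethylamino on a Mirror-Image Pair

The source may hold more compounds than are shown below. What is called first, only, known or untested is meant among the compounds shown, and "the series" means these compounds.

Compound 3 `CCNC(=O)Nc1ccc(-c2nc(C(C)(C)S(C)(=O)=O)cc([C@]34CCOC[C@H]3C4)n2)cc1` gives 4.7 in a physicochemical assay for lipophilicity; on this read-out higher numbers stand for higher lipophilicity and lower numbers for lower lipophilicity. Compound 1 `CNCC(=O)Nc1ccc(-c2nc(C(C)(C)S(C)(=O)=O)cc([C@]34CCOC[C@H]3C4)n2)cc1` shares its core and differs by (methylamino)methyl in place of ethylamino on a carbonyl carbon; in this assay compound 1 gives 4.3, so that a number 0.40 log units lower from compound 3 to compound 1 (beyond the scatter). Compound 2 `CCNC(=O)Nc1ccc(-c2nc(C(C)(C)S(C)(=O)=O)cc([C@@]34CCOC[C@@H]3C4)n2)cc1` stands to compound 3 as the two compounds have the same atoms and bonds and differ only in configuration as drawn: 2 of 2 stereo elements differ (all stereocentres are inverted: mirror images); a stereocentre at a saturated ring carbon is drawn R in compound 3 and S in compound 2; a stereocentre at a saturated ring carbon is drawn S in compound 3 and R in compound 2, and in this assay compound 2 gives 4.7; no change at the digits printed from compound 2 to compound 3 (within the scatter), which sits well with the fact that compounds 2 and 3 differ only in the configuration as drawn. Compound 4 `CNCC(=O)Nc1ccc(-c2nc(C(C)(C)S(C)(=O)=O)cc([C@@]34CCOC[C@@H]3C4)n2)cc1` is not yet measured. Among the measured compounds shown here, it differs from compound 2 by (methylamino)methyl in place of ethylamino on a carbonyl carbon, the same kind of change, at the same place, as the one from compound 3 to compound 1. Since compound 2 in this assay gives 4.7, level with compound 3, the expected step is a number 0.40 log units lower from compound 2 to compound 4 (beyond the scatter), the same size as the measured one. Compound 4 is therefore estimated at 4.3, likely between 4 and 4.6.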

Compound 4, partition coefficient: 4.3
Estimate against measurement, compound 4: no gap at the digits printed; low and high end bracket the measured number.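

In this assay, (methylamino)methyl in place of ethylamino on a carbonyl carbon gives a number 0.40 log units lower from compound 2 to compound 4 (beyond the scatter), the same size as a number 0.40 log units lower from compound 3 to compound 1 (beyond the scatter), so the change carries over between these two mirror-image cores. The other new step reads no change at the digits printed from compound 1 to compound 4 (within the scatter), which fits what separates that pair: the fact that compounds 1 and 4 differ only in the configuration as drawn. This is a narrow test, however: the two cores have the same atoms and bonds, so it shows nothing about a core built differently, and two matching steps make no general rule.

Still open, from the compounds shown here alone, is how a longer chain such as propylamino, or a carboxylic acid, on that carbonyl carbon would read in this assay.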